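The source may report more compounds than this note shows. Statements on the series, on what has been measured and on what is new or still open speak of the compounds shown alone.

Compound 1 `CCCCc1ccc(-c2cc(-c3cn([C@H]4C[C@H](OC(C)=O)[C@@H](COC(C)=O)O4)c(=O)[nH]c3=O)on2)cc1` was examined in a functional assay on NUGC-3 cells (Homo sapiens) for cytotoxicity, read by sulforhodamine B assay, tested at 10 uM (a lower number here means less inhibition, a higher number more inhibition at the concentration tested (going by the name of the read-out)), where compound 1 gives 39.8%. Among the compounds with values here, of the two compounds measured so far, compound 1 stands lowest. The other, compound 2 `CC(=O)OC[C@H]1O[C@@H](n2cc(-c3cn(Cc4ccc(C(C)(C)C)cc4)nn3)c(=O)[nH]c2=O)C[C@@H]1OC(C)=O`, gives 94.2% in this assay, a number that lies beyond the usual scatter above that of compound 1. These two compounds differ at more than one place, so their gap cannot be assigned to any single change.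

Compound 3 `CC(=O)OC[C@H]1O[C@@H](n2cc(-c3cc(-c4ccccc4)no3)c(=O)[nH]c2=O)C[C@@H]1OC(C)=O` has not yet been measured. It differs from compound 1 in one place only: hydrogen in place of butyl on an aromatic carbon. Within the data shown here, no measured pair here isolates what that change does. The step expected in this assay is a number 9.8 percentage points lower from compound 1 to compound 3 (within the scatter), small and downward, and it may well stay within the scatter. Compound 3 is therefore estimated to give 30% in this assay, within a range from 10% to 55%.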

Compound 3, a percentage reported as inhibition, at one concentration (the size of the read-out at that concentration, not a potency): 87.6%
Estimate against measurement, compound 3: 57.6 percentage points below; measured number above the stated range.
By their numbers in this assay, from the lowest: compound 1; then compounds 3 and 2 (each within the scatter of the next).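

Within the data shown here, replacing butyl with hydrogen, which turns 4-butylphenyl into phenyl, gives in this assay a number that is a number 47.8 percentage points higher from compound 1 to compound 3 (beyond the scatter) and so is the first reading of a single change in this set. It shows that this position, para to a large group, is not a silent one: the compound without the butyl chain inhibits far more at the concentration tested. Nothing at hand gives a measured reason for this step.

The compounds shown leave open whether any group at this position lowers the inhibition or whether this depends on the chain's length, which a methyl group, a propyl chain or a longer chain would test. They also leave open whether a methoxy group or an amine at the same place would behave like butyl or like hydrogen.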